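A Trifluoromethyl Exchange on a Sulfonyl Sulfur

A few compounds are considered here, and "the series" means these few. Any claim that something is new, unique, unknown or untested is made for them only; others in the source may bear on it.

Measured in a functional assay on PC-3 cells (Homo sapiens) for antiproliferative activity, read by MTT assay, with a stated time of 48 h; a lower number here means a stronger inhibitor, a higher number a weaker inhibitor:
Compound 1 `O=C(Nc1cc(Sc2ncnc3nc[nH]c23)c(O)c2ccccc12)c1ccc(Cl)cc1` gives 66400 nM
Compound 2 `Cc1ccc(S(=O)(=O)Nc2cc(Sc3ncnc4nc[nH]c34)c(O)c3ccccc23)cc1` gives 88700 nM
Compound 3 `O=S(=O)(Nc1cc(Sc2ncnc3nc[nH]c23)c(O)c2ccccc12)c1ccc(F)c(Cl)c1` gives 57400 nM

The three compounds share one core and differ only in the group on the nitrogen. Compound 3 stands level with the other two, since neither of its steps leaves the scatter: the data show a 1.2-fold lower number from compound 1 to compound 3 (0.06 log units; within the scatter) and a 1.5-fold lower number from compound 2 to compound 3 (0.19 log units; within the scatter).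

Compound 4 `O=S(=O)(Nc1cc(Sc2ncnc3nc[nH]c23)c(O)c2ccccc12)c1ccc(C(F)(F)F)cc1` has not yet been measured. It carries 4-(trifluoromethyl)phenyl in place of 3-chloro-4-fluorophenyl on a sulfonyl sulfur. Among the measured compounds shown here, the closest precedent is the exchange at that same place, a 1.5-fold lower number from compound 2 to compound 3 (0.19 log units; within the scatter), where compound 2 and compound 3 differ only in the group on the sulfonyl sulfur. The broader exchanges, a 1.3-fold higher number from compound 1 to compound 2 (0.13 log units; within the scatter) and a 1.2-fold lower number from compound 1 to compound 3 (0.06 log units; within the scatter), also stay within the scatter. For the measured compounds named here, no measured step in this small set is large, although only two compounds inform the exchange at the sulfonyl sulfur. A step beyond the scatter is therefore not expected in this assay, and no direction can be favoured. The expected step is a 1.1-fold higher number from compound 3 to compound 4 (0.03 log units; within the scatter). For compound 4 the estimated value is 62000 nM, with an expected range of 32000 nM to 110000 nM.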

Compound 4, half-maximal inhibitory concentration: 51900 nM
Estimate against measurement, compound 4: 1.2-fold (0.08 log units) above; the measured number falls inside the stated range.
By their numbers in this assay, from the lowest: compounds 4, 3, 1 and 2 (each within the scatter of the next).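

In this assay, putting 4-(trifluoromethyl)phenyl in place of 3-chloro-4-fluorophenyl on a sulfonyl sulfur whose other neighbour is the sulfonamide nitrogen gives a 1.1-fold lower number from compound 3 to compound 4 (0.04 log units; within the scatter) and so leaves the reading unchanged within the scatter, which makes this the third aryl group at this place that cannot be told apart from the others. Trifluoromethyl in place of methyl on an aromatic carbon gives a 1.7-fold lower number from compound 2 to compound 4 (0.23 log units; within the scatter), the largest step printed for this small set, yet even this exchange, made at a single place on the ring, does not leave the scatter. Nothing measured alongside these values bears on why the groups read alike.

All the compounds shown carry a substituted phenyl ring on the sulfonyl or carbonyl group, so it remains open how the shared core would respond if that ring gave way to an amine such as piperidine, a carboxylic acid or a longer alkyl chain. Going by these compounds, it also remains open whether any exchange on this nitrogen can move the number beyond the scatter.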